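Chloro to Fluoro: A Small Halogen Swap

The compounds below may be only part of what the source reports. "The series", "measured", "known", "first", "only" and "open" are said of these compounds alone.

Compound 1 `CN1CCN(CCCOc2cccc3nc(Nc4ccc(Cl)c(C(F)(F)F)c4)ccc23)CC1` and compound 2 `CN1CCN(CCCOc2cccc3nc(Nc4ccc(Cl)c(F)c4)ccc23)CC1` share the same core and differ in one substituent. In a functional assay on cells (Panel prostate (Carcinoma cell lines), Homo sapiens) for inhibition, read by sulforhodamine B assay, with a stated time of 48 h (a higher number here means a weaker inhibitor of growth, a lower number a stronger inhibitor of growth), compound 1 gives 3150 nM, and in this assay compound 2 gives 2800 nM. The step of a 1.1-fold lower number from compound 1 to compound 2 (0.05 log units; within the scatter), fluoro in place of trifluoromethyl, lies within the scatter. Among the compounds with values here, compound 2 has the lower of the two numbers, yet its only neighbour is within the scatter, so no order between the two can be claimed.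

Compound 3 `CN1CCN(CCCOc2cccc3nc(Nc4ccc(F)c(F)c4)ccc23)CC1` has not been measured. It differs from compound 2 by fluoro in place of chloro on an aromatic carbon. Within the data shown here, the only measured step, a 1.1-fold lower number from compound 1 to compound 2 (0.05 log units; within the scatter), involves a different group and was small, so a halogen swap at a neighbouring spot is expected to change little beyond the scatter. Compound 3 is therefore estimated at 3500 nM in this assay, between 1500 nM and 9000 nM, an expected step of a 1.3-fold higher number from compound 2 to compound 3 (0.10 log units; within the scatter).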

Compound 3, concentration for total growth inhibition: 8550 nM
Beside the measured number, compound 3's estimate is 2.4-fold (0.39 log units) below it; low and high end bracket the measured number.
By their numbers in this assay, from the lowest: compounds 2 and 1 (each within the scatter of the next); then compound 3.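

Swapping chloro for fluoro at the site para to a large group gives a 3.1-fold higher number from compound 2 to compound 3 (0.48 log units; beyond the scatter) in this assay, so this one-atom change moves the number beyond the scatter, unlike the earlier 1.1-fold lower number from compound 1 to compound 2 (0.05 log units; within the scatter). With a 2.7-fold higher number from compound 1 to compound 3 (0.43 log units; beyond the scatter) as well, the two compounds that keep the chloro lie within the scatter of each other, while compound 3, with fluoro at that site, is the weaker inhibitor of growth. No measurement offered here explains why this site responds to the swap.

Going by these compounds, only chloro and fluoro have been compared at this site, so it remains open whether a bromo or a methyl group there would match compound 2 or give a lower number. On these data alone, how an amine at the same site would behave also remains open.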